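The source may report more compounds than this note shows. Statements on the series, on what has been measured and on what is new or still open speak of the compounds shown alone.

In a functional assay on CCRF-CEM cells (Homo sapiens) (on this read-out higher numbers stand for weaker inhibition and lower numbers for stronger inhibition), compound 1 `Cc1ccc(-c2ncnc3c2ncn3C[C@@H]2C[C@H](CO)c3ccccc32)cc1` gives 1.4 ug/mL and compound 2 `CC(C)Nc1ncnc2c1ncn2C[C@@H]1C[C@H](CO)c2ccccc21` gives 24 ug/mL as the higher of the two numbers, which means weaker inhibition. Among the measured compounds shown here, the only measured step is a 17-fold higher number from compound 1 to compound 2 (1.23 log units; beyond the scatter) and it is large, but it swaps a whole group, isopropylamino in place of 4-methylphenyl on an aromatic carbon. Compound 3 `CCCNc1ncnc2c1ncn2C[C@@H]1C[C@H](CO)c2ccccc21` differs from compound 2 far less, as propyl in place of isopropyl on a nitrogen on an aromatic ring shows: propyl in place of isopropyl on a nitrogen on an aromatic ring, with the same atoms joined differently. For the measured compounds named here, no measured step covers this swap, so the expectation rests on compound 2 at 24 ug/mL and is a change within the usual scatter, in no firm direction. The expected step is a 1.1-fold lower number from compound 2 to compound 3 (0.06 log units; within the scatter) in this estimate. For compound 3 the estimated value is 21 ug/mL with 9 ug/mL to 48 ug/mL as its range.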

Compound 3, half-maximal inhibitory concentration: 24 ug/mL
Beside the measured number, compound 3's estimate is 1.1-fold (0.06 log units) below it; the range from low to high includes it.
By their numbers in this assay, from the lowest: compound 1; then compounds 2 and 3 (each within the scatter of the next).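

In this assay the swap of isopropyl for propyl on the nitrogen gives no change at the digits printed from compound 2 to compound 3 (within the scatter) and so shows that, for these two chains, how the three carbons are joined makes no difference this read-out can detect. The step of a 17-fold higher number from compound 1 to compound 3 (1.23 log units; beyond the scatter) has the same size as the one seen earlier with isopropylamino, so the large gap to the 4-methylphenyl compound now holds for two amino groups rather than one. Nothing available explains either result.

Still open, going by these compounds, is whether the flat response extends to other groups on this nitrogen, such as a shorter ethyl chain, a longer butyl chain or a cyclopropyl ring. It is also unclear whether the stronger inhibition seen with 4-methylphenyl needs its methyl, which a plain phenyl group would test.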